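Amine to dimethylamine on a urea-linked cyclopentyl aryl group

The source may hold more compounds than are shown below. What is called first, only, known or untested is meant among the compounds shown, and "the series" means these compounds.

Measured compounds:
Compound 1 `CC(C)c1cccc(C(C)C)c1NC(=O)NCC1(c2ccc(C(C)(C)C)cc2)CCCC1` gives 63 nM in an assay on microsomes for inhibition of acyl-CoA:cholesterol acyltransferase (Oryctolagus cuniculus); a higher number here means a weaker inhibitor, a lower number a stronger inhibitor.
Compound 2 `CC(C)c1cccc(C(C)C)c1NC(=O)NCC1(c2cccc(N)c2)CCCC1` gives 21 nM in this assay.

Going by the values given here, compound 2 holds the lower of the two numbers, the single measured step being a 3.0-fold lower number from compound 1 to compound 2 (0.48 log units; beyond the scatter). Compound 3 `CC(C)c1cccc(C(C)C)c1NC(=O)NCC1(c2cccc(N(C)C)c2)CCCC1` carries dimethylamino in place of amino on an aromatic carbon. Among the compounds with values here, no measured step makes this same change; the one step known, which swaps the whole aryl group, was only modest, so the aryl end tolerates change. For compound 3 the expected step is a 1.2-fold higher number from compound 2 to compound 3 (0.08 log units; within the scatter), within the scatter. Compound 3 is thus estimated at 25 nM, ranging from 8 nM to 80 nM.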

Compound 3, half-maximal inhibitory concentration: 33 nM
The estimate for compound 3 lay 1.3-fold (0.12 log units) below the measured number, and the stated range covers the measured number.
By their numbers in this assay, from the lowest: compounds 2, 3 and 1 (each within the scatter of the next, the first and the last beyond it).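

In this assay, dimethylamino in place of amino gives a 1.6-fold higher number from compound 2 to compound 3 (0.20 log units; within the scatter), so this position accepts the larger group, which has no hydrogen-bond donor, without a change that stands out from the scatter. The 3-(dimethylamino)phenyl group also gives a 1.9-fold lower number from compound 1 to compound 3 (0.28 log units; within the scatter), so, unlike 3-aminophenyl, it cannot be told apart from 4-(tert-butyl)phenyl. No supporting data bear on why the two amines give such similar results. Still open, from the compounds shown here alone, is whether an acetamide or a carboxylic acid in this place would fit as well, and whether a diethylamino group would.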